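Nitrophenyl for Ethoxyphenyl on the Triazole Nitrogen

A few compounds are considered here, and "the series" means these few. Any claim that something is new, unique, unknown or untested is made for them only; others in the source may bear on it.

Measured compounds:
compound 1 `CCOc1ccccc1-n1nncc1CN1C(=O)C2(C(C#N)=C(N)Oc3c2c2nc4ccccc4nc2c2ccccc32)c2ccccc21`, > 50000 nM
compound 2 `N#CC1=C(N)Oc2c(c3nc4ccccc4nc3c3ccccc23)C12C(=O)N(Cc1cnnn1-c1ccc([N+](=O)[O-])cc1)c1ccccc12`, > 50000 nM
compound 3 `CCOc1ccccc1-n1nncc1CN1C(=O)C2(C(C#N)=C(N)Oc3c(N)cc4nc5ccccc5nc4c32)c2ccccc21`, 30500 nM

In a functional assay on HepG2 cells (Homo sapiens) for antiproliferative activity, read by MTT assay, with a stated time of 48 h (on this read-out higher numbers stand for weaker inhibition and lower numbers for stronger inhibition), compound 1 returns only a limit, > 50000 nM. Compound 2 likewise returns only a limit, > 50000 nM. Within the data shown here, compound 3 is the one compound with a number, giving 30500 nM in this assay. Between compound 1 and compound 2 the change is 4-nitrophenyl in place of 2-ethoxyphenyl on an aromatic nitrogen, and the step is a step that the two limits leave unreadable from compound 1 to compound 2. The difference between the core of compound 1 and the core of compound 3 is not broken down here. Compound 4 `N#CC1=C(N)Oc2c(N)cc3nc4ccccc4nc3c2C12C(=O)N(Cc1cnnn1-c1ccc([N+](=O)[O-])cc1)c1ccccc12` carries the same change on the core of compound 3: 4-nitrophenyl in place of 2-ethoxyphenyl on an aromatic nitrogen. Because of the limit of > 50000 nM in this assay, at which 2 of the 3 values shown sit, the size of that change is not readable from the measured pair, so the expectation for compound 4 rests on compound 3 and its value 30500 nM together with the unreadable step that the two limits leave unreadable from compound 1 to compound 2. The expected step from compound 3 is a 1.3-fold higher number from compound 3 to compound 4 (0.12 log units; within the scatter), with a wide range. Compound 4 is estimated at 40000 nM in this assay, between 12000 nM and 150000 nM.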

Compound 4, half-maximal inhibitory concentration: > 50000 nM
Compound 4: a limit, no number; the forecaster's own chance of this, stated with the estimate: 45%; middle value at least 1.2-fold (0.09 log units) from the limit.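

In this assay, 4-nitrophenyl in place of 2-ethoxyphenyl on an aromatic nitrogen of the core of compound 3 gives an at least 1.6-fold higher number from compound 3 to compound 4 (0.21 log units; that floor lies within the scatter). Compound 4 gives > 50000 nM, which is a limit of the assay and not a number. The same change on the core of compound 1 cannot be read, so the compounds do not show whether the change has the same size on the two cores, and the step on the core of compound 3 has only a floor because the values sit at the limit: the limit of > 50000 nM in this assay, at which 3 of the 4 values shown sit.

Among the compounds shown, only compound 3 gives a number, 30500 nM, so it remains open how far the group on that aromatic nitrogen can move the read-out on this core. A plain phenyl or a 4-aminophenyl at the same place would test whether any number can be obtained on the core of compound 1 and how the number on the core of compound 3 responds.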